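The compounds below may be only part of what the source reports. "The series", "measured", "known", "first", "only" and "open" are said of these compounds alone.

Compound 1, `Fc1ccc2c(c1CNc1ncc(Oc3ccccc3)c3nncn13)CCO2`, was examined in an ADME assay on microsomes from liver (Homo sapiens) for metabolic stability, read by LC-MS, using NADPH, with stated times of 5 min and 30 min, tested at 1 uM (a higher number here means faster removal of the compound, a lower number slower removal), where compound 1 gives 18 mL.min-1.g-1. Going by the values given here, the only other compound with a measurement in this assay is compound 2, `Cc1nn(C)cc1-c1cnc(NCc2c(F)ccc3c2CCO3)c2cn[nH]c(=O)c12`, and in this assay compound 2 gives 27 mL.min-1.g-1; the two numbers lie within the usual scatter of each other, so neither compound can be said to be cleared faster or slower than the other. Compound 3, `COCCC(=O)Nc1cnc(NCc2c(F)ccc3c2CCO3)n2cnnc12`, has not yet been measured. It differs from compound 1 in one place: ((2-methoxyethyl)carbonyl)amino in place of phenoxy on an aromatic carbon. Among the compounds with values here, no measured pair in this set shares that change, so nothing here shows how large a step it brings. The account therefore expects a step from compound 1 to compound 3 of a 1.4-fold lower number from compound 1 to compound 3 (0.14 log units; within the scatter) in this assay, small and probably toward slower removal, though it may fall inside the scatter. For compound 3 the estimated value in this assay is 13 mL.min-1.g-1, with a likely range from 6 mL.min-1.g-1 to 30 mL.min-1.g-1.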

Compound 3, intrinsic clearance in microsomes: < 3 mL.min-1.g-1
Compound 3 gave a limit, no number; the forecaster's own chance of this, stated with the estimate: 10%; at least 4.3-fold (0.63 log units) between middle value and limit.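

In this assay, ((2-methoxyethyl)carbonyl)amino in place of phenoxy on this aromatic carbon brings an at least 6.0-fold lower number from compound 1 to compound 3 (0.77 log units; beyond the scatter), so this position, para to a large group, can strongly shift the intrinsic clearance in microsomes. The step comes with no change in the count of heavy atoms, while a six-membered aromatic ring of carbon leaves and a hydrogen-bond donor and a double bond outside aromatic rings enter. Compound 3 gives a limit of the assay, not a number, so the true size of the step stays unknown: the limit of < 3 mL.min-1.g-1 in this assay, at which 1 of the 3 values shown sits.

Going by these compounds alone, the single exchange does not show which of these differences carries the step. As far as these compounds go, whether a plain amine, an acetylamino group or a benzoylamino group, which keeps an aromatic ring alongside the amide hydrogen, would behave like compound 3 remains open.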